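The compounds below may be only part of what the source reports. "The series", "measured", "known", "first", "only" and "open" are said of these compounds alone.

Compound 1 `CC(/C=N/Nc1ccc([N+](=O)[O-])cc1)=N\NC(=O)c1ccc(O)cc1` and compound 2 `CC(/C=N/Nc1ccc([N+](=O)[O-])cc1)=N\NC(=O)c1ccc(C(C)(C)C)cc1` share one core and differ in a single group on an aromatic carbon. In an ADME assay on J774 cells (Mus musculus, strain BALB/c) for cytotoxicity, read by resazurin assay, with a stated time of 72 h (a higher number here means that more compound is tolerated, a lower number that less compound is tolerated), compound 1 gives 51000 nM. In this assay compound 2 gives > 100000 nM, and that is a limit of the assay rather than a number; this is the limit of > 100000 nM in this assay, at which 1 of the 2 values shown sits. Among the compounds with values here, the only measured step is an at least 1.9-fold higher number from compound 1 to compound 2 (0.29 log units; that floor lies within the scatter). Compound 3 `CC(/C=N/Nc1ccc([N+](=O)[O-])cc1)=N\NC(=O)c1ccc(C(F)(F)F)cc1` differs from compound 2 by trifluoromethyl in place of tert-butyl on an aromatic carbon. Within the data shown here, no measured step exchanges one such group for another, and the one step that is known reaches no further than its floor, so little can be read from it. The step of a number no higher from compound 2 to compound 3 (the limit leaves the size open) is therefore expected to be none beyond the scatter. Compound 3 is expected to give about 100000 nM in this assay, within a range from 40000 nM to 250000 nM, with a real chance that again only a limit is reported.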

Compound 3, half-maximal cytotoxic concentration: 78700 nM
The estimate for compound 3 lay 1.3-fold (0.10 log units) above the measured number, and the stated range covers the measured number.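

Compound 3 gives a second measured number for a group on this aromatic carbon, and it shows that trifluoromethyl and hydroxy cannot be told apart in this assay: the change gives a 1.5-fold higher number from compound 1 to compound 3 (0.19 log units; within the scatter). Exchanging tert-butyl for trifluoromethyl gives an at least 1.2-fold lower number from compound 2 to compound 3 (0.10 log units; that floor lies within the scatter), so that floor shows no change beyond the scatter. The real size of this step stays unknown because the value of compound 2 is a limit and not a number: the limit of > 100000 nM in this assay, at which 1 of the 3 values shown sits.

From the compounds shown here alone, whether an amine or a carboxylic acid on this aromatic carbon would move the number beyond the scatter remains open. Also open is how far compound 2 truly lies from compound 1 and compound 3, and what, if anything, sets the small differences among these numbers.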